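This account rests on a few compounds, and the source may have more. Where it says the series, first, only, none or still open, it means among the compounds named here.

Three compounds have been measured in a functional assay on LS174T cells (Homo sapiens) for inhibition, with a stated time of 4 days, tested at 1 uM; a higher number here means a stronger effect of the compound at the concentration tested, a lower number a weaker effect:
compound 1, `CN(C)c1ccc2cc(C#Cc3c(F)cccc3F)ccc2n1`, 2%;
compound 2, `Fc1cccc(F)c1C#Cc1cncc2ccccc12`, 16.5%;
compound 3, `CN(C)c1ncc(C#Cc2c(F)cccc2F)c2ccccc12`, 99.5%.

Compound 3 stands far above the other two. The move from compound 3 to compound 2 is hydrogen in place of dimethylamino on an aromatic carbon and produces a number 83 percentage points lower from compound 3 to compound 2 (beyond the scatter). Compound 1 has the same atoms as compound 3 joined differently; the difference between the two cores is not broken down here. Compound 1 gives the lowest number of the three, with compound 2 above it beyond the scatter.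

Compound 4, `Fc1cccc(F)c1C#Cc1ccc2ncccc2c1`, has not yet been measured. Relative to compound 1 it shows (hydrogen in place of dimethylamino on an aromatic carbon). This is the same kind of change as from compound 3 to compound 2, but not the same: in compound 3 the carbon is ortho to a fused ring, meta to a fused ring and para to a large group, whereas in compound 1 it is meta to a fused ring and para to a fused ring. In this assay the earlier step was large, yet compound 1 already gives 2%, which leaves almost no room below it. The step is therefore expected to be small, a number 1 percentage points higher from compound 1 to compound 4 (within the scatter). Compound 4 is estimated at 3%, most likely between 0% and 15%.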

Compound 4, a percentage reported as inhibition, at one concentration (the size of the read-out at that concentration, not a potency): 11%
The estimate for compound 4 lay 8 percentage points below the measured number; low and high end bracket the measured number.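

In this assay, replacing dimethylamino with hydrogen does not behave alike on the two cores: the same change on two cores in this assay, a number 83 percentage points lower (beyond the scatter) from compound 3 to compound 2 and a number 9 percentage points higher (within the scatter) from compound 1 to compound 4, 92 percentage points apart, beyond the scatter of two such steps. On the second core the change gives a number 9 percentage points higher from compound 1 to compound 4 (within the scatter), so no loss is seen there, although the low starting value leaves little room for one. This shows that the large drop on the core of compound 3 cannot be assumed to carry over to another core in this series, but it does not show why the two steps part, and a single pair on each core gives no rule for a third core.

The compounds shown leave open whether the high value of compound 3 depends on dimethylamino in particular or would hold for other groups on that carbon. A smaller amine such as methylamino, a cyclic amine such as morpholine, or a methoxy group in that place would bear on this question, and the same groups on the core of compound 1 would show whether the two cores keep differing.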